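Propoxy on the Fused Ring of a Chromone Sulfoxide

A few compounds are considered here, and "the series" means these few. Any claim that something is new, unique, unknown or untested is made for them only; others in the source may bear on it.

Measured compounds:
- compound 1, `C[S+]([O-])/C=C/c1cc(=O)c2ccccc2o1` — 8000 nM
- compound 2, `Cc1c(/C=C/[S+](C)[O-])oc2ccccc2c1=O` — 7200 nM
- compound 3, `C[S+]([O-])/C=C/c1oc2ccccc2c(=O)c1Cc1ccccc1` — 5100 nM

In a functional assay on DLD-1 cells (Homo sapiens) for cytotoxicity, with a stated time of 48 h (a lower number here means a stronger inhibitor, a higher number a weaker inhibitor), compound 1 gives 8000 nM, the highest of the three numbers. Its nearest neighbour is compound 2, with a 1.1-fold lower number from compound 1 to compound 2 (0.05 log units; within the scatter), and its furthest is compound 3, with a 1.6-fold lower number from compound 1 to compound 3 (0.20 log units; within the scatter); both steps stay within the scatter, as does a 1.4-fold lower number from compound 2 to compound 3 (0.15 log units; within the scatter).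

Compound 4, `CCCOc1ccc2oc(/C=C/[S+](C)[O-])cc(=O)c2c1`, has not yet been measured. It differs from compound 1 by propoxy in place of hydrogen on an aromatic carbon. For the measured compounds named here, none of the measured steps touches this position: the changes from compound 1 to compound 2 and from compound 1 to compound 3 were made on a different carbon of the shared core, and each stayed within the scatter. What they show is that the core of compound 1 has so far tolerated additions without a step beyond the scatter, so the expectation for compound 4 in this assay is a number close to that of compound 1, with the step of a 1.2-fold lower number from compound 1 to compound 4 (0.09 log units; within the scatter) expected to fall within the scatter. Compound 4 is therefore estimated at 6500 nM, in a range from 3000 nM to 14000 nM.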

Compound 4, half-maximal inhibitory concentration: 6200 nM
The estimate for compound 4 lay 1.0-fold (0.02 log units) above the measured number, and the stated range covers the measured number.
By their numbers in this assay, from the lowest: compounds 3, 4, 2 and 1 (each within the scatter of the next).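

Compound 4 places a group on a part of the shared core that compound 2 and compound 3 leave unchanged: propoxy on an aromatic carbon of the six-membered aromatic ring of carbon only. In this assay, this change gives a 1.3-fold lower number from compound 1 to compound 4 (0.11 log units; within the scatter), so this position, like the carbon changed in compound 2 and compound 3, takes an addition without a step beyond the scatter. No measurement is at hand that would explain the result.

A single group at one position leaves open whether methoxy, a longer chain such as hexyloxy, an amine or a carboxylic acid on the same carbon would also stay within the scatter. It also leaves open whether propoxy on another carbon of this ring would do the same.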